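The source may hold more compounds than are shown below. What is called first, only, known or untested is meant among the compounds shown, and "the series" means these compounds.

Measured compounds and their values:

Compound 1, `COCCOc1cc2oc(=O)n(CCC(=O)O)c2cc1Cl`: 0.88
Compound 2, `C[C@@H](Oc1cc2oc(=O)n(CCC(=O)O)c2cc1Cl)c1ccc(F)cn1`: 1.98
Compound 3, `O=C(O)CCn1c(=O)oc2cc(OCc3ccccc3)c(Cl)cc21`: 2.71

All three share one core and differ only in the group attached through an oxygen on the aromatic ring. In a physicochemical assay for lipophilicity, read by HPLC, at pH 7.4 (a higher number here means a more lipophilic compound, a lower number a more polar compound), compound 3 gives the highest of the three numbers: compound 2 stands nearest, and compound 1 lies furthest away, both gaps beyond the scatter. Going by the values given here, the one step between compounds that differ in a single place is a number 1.83 log units higher from compound 1 to compound 3 (beyond the scatter), a large rise.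

Compound 4, `CCOc1cc2oc(=O)n(CCC(=O)O)c2cc1Cl`, has not yet been measured. It differs from compound 3 as follows:

methyl in place of phenyl on a saturated chain carbon bound to an oxygen on an aromatic ring

This change runs opposite in spirit to the step from compound 1 to compound 3, since that step brought a phenyl in and this one takes the phenyl away, leaving only a methyl. The large rise seen there therefore points to a large fall of comparable size here in this assay for compound 4. The estimated step is a number 1.31 log units lower from compound 3 to compound 4 (beyond the scatter), so compound 4 is expected to land at about 1.4, within a range from 1 to 1.8.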

Compound 4, distribution coefficient: 1.49
Estimate against measurement, compound 4: 0.09 log units below; low and high end bracket the measured number.
By their numbers in this assay, from the lowest: compound 1; then compound 4; then compound 2; then compound 3.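

With compound 4, this position gains a small, plain ethoxy group against which the other three groups can be read. In this assay, changing benzyloxy to ethoxy gives a number 1.22 log units lower from compound 3 to compound 4 (beyond the scatter) and is a large step, replacing the 5-fluoropyridin-2-yl group with hydrogen gives a number 0.49 log units lower from compound 2 to compound 4 (beyond the scatter) and is a modest one, and replacing the methoxy on the chain of compound 1 with hydrogen gives a number 0.61 log units higher from compound 1 to compound 4 (beyond the scatter) and is also modest, so the two groups carrying a ring stand above the ethoxy while the chain carrying a methoxy stands below it. Nothing measured here explains these differences in size and direction.

On these data alone, it remains open how the number would move with a longer chain such as propyl or butyl in place of the ethyl, and whether a plain phenyl would behave like the 5-fluoropyridin-2-yl group if each sat on the same chain. An amine or a carboxylic acid at the end of the ethoxy chain would also test whether the fall seen with the methoxy extends to other groups.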